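A few compounds are considered here, and "the series" means these few. Any claim that something is new, unique, unknown or untested is made for them only; others in the source may bear on it.

Of the compounds shown here, two built on a shared core have so far been measured in an assay on cells for activation of nuclear factor erythroid 2-related factor 2 (Homo sapiens), read by MTT assay, with a stated time of 48 h; a lower number here means that less compound is needed, a higher number that more compound is needed for the effect. In this assay compound 1 `COc1cc(C(CC(=O)O)c2cccc(CN3CC(C)Oc4ccccc4S3(=O)=O)c2)cc2nnn(C)c12` gives 2900 nM. In this assay compound 2 `COc1cc(C(CC(=O)O)c2ccc(C)c(CN(C)S(=O)(=O)c3ccccc3)c2)cc2nnn(C)c12` gives 850 nM, the lower of the two numbers; its nearest neighbour is compound 1, whose value lies beyond the usual scatter above it. Compound 3 `Cc1ccc(C(CC(=O)O)c2ccc3c(c2)nnn3C)cc1CN(C)S(=O)(=O)c1ccccc1` has not been measured. It differs from compound 2 in one place: hydrogen in place of methoxy on an aromatic carbon. For the measured compounds named here, no pair of measured compounds probes this change, so nothing in the data shows how the methoxy group bears on the read-out. The writer therefore expects only a moderate step, most likely towards a higher number, of a size that may or may not exceed the scatter of repeated measurements: the step of a 1.8-fold higher number from compound 2 to compound 3 (0.25 log units; within the scatter) is his estimate. Going by the values given here, for compound 3 in this assay he estimates 1500 nM, with a range from 500 nM to 4500 nM to cover the uncertainty of a change that no measured pair has tested.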

Compound 3, half-maximal effective concentration: 3400 nM
For compound 3 the middle estimate is 2.3-fold (0.36 log units) below the measured one; measured number inside the range.
By their numbers in this assay, from the lowest: compound 2; then compounds 1 and 3 (each within the scatter of the next).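

Replacing methoxy with hydrogen on this aromatic carbon, meta to a large group, gives a 4.0-fold higher number from compound 2 to compound 3 (0.60 log units; beyond the scatter) in this assay, a modest step that lies beyond the usual scatter. Compound 1 and compound 2 differ in more than one place, so this pair is the first among the compounds shown to isolate the position, and it shows that, with the rest of compound 2 unchanged, the compound carrying methoxy is the one that needs less compound for the effect. Nothing available explains this step or says what the methoxy group does at this carbon.

The compounds shown leave open whether the gain belongs to methoxy itself or would also appear with another group at this carbon, such as a hydroxyl, an ethoxy, a fluorine atom or an amine, since hydrogen is the only replacement shown here. They also leave open whether removing methoxy would give a similar step in the setting of compound 1, where the sulfonamide part of the molecule is built differently from that of compound 2.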